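Varying the aryl group on the triazole nitrogen

The source may report more compounds than this note shows. Statements on the series, on what has been measured and on what is new or still open speak of the compounds shown alone.

Compound 1 `Cc1ccccc1-n1nncc1CN1C(=O)C2(C(C#N)=C(N)Oc3c2c2nc4ccccc4nc2c2ccccc32)c2ccccc21`: in a functional assay on HCT-116 cells (Homo sapiens) for antiproliferative activity, read by MTT assay, with a stated time of 48 h (on this read-out lower numbers stand for stronger inhibition and higher numbers for weaker inhibition), compound 1 gives > 50000 nM, which is a limit of the assay.
Compound 2 `N#CC1=C(N)Oc2c(c3nc4ccccc4nc3c3ccccc23)C12C(=O)N(Cc1cnnn1-c1cccc(S(N)(=O)=O)c1)c1ccccc12`: in this assay compound 2 gives 11300 nM.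

Compound 2 stands as the only number shown; the other result is a limit, see (the limit of > 50000 nM in this assay, at which 1 of the 2 values shown sits). Compound 3 `Cc1ccc(-n2nncc2CN2C(=O)C3(C(C#N)=C(N)Oc4c3c3nc5ccccc5nc3c3ccccc43)c3ccccc32)cc1C` differs from compound 2 by 3,4-dimethylphenyl in place of 3-sulfamoylphenyl on an aromatic nitrogen. Among the measured compounds shown here, the single measured step bears on this change in reverse: an at least 4.4-fold lower number from compound 1 to compound 2 (0.64 log units; beyond the scatter). Going back from 3-sulfamoylphenyl to a methyl-bearing phenyl, as in compound 1, therefore points to a higher number again, possibly up at the limit. Compound 3 is expected to give 40000 nM, between 12000 nM and 120000 nM, an expected step of a 3.5-fold higher number from compound 2 to compound 3 (0.55 log units; beyond the scatter).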

Compound 3, half-maximal inhibitory concentration: > 50000 nM
Compound 3: no number, only a limit; the forecaster's own chance of this, stated with the estimate: 45%; at least 1.2-fold (0.09 log units) between middle value and limit.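

The change from 3-sulfamoylphenyl to 3,4-dimethylphenyl on the aromatic nitrogen gives an at least 4.4-fold higher number from compound 2 to compound 3 (0.64 log units; beyond the scatter), so a second phenyl group carrying only methyl groups ends up with 2-methylphenyl at the limit: the limit of > 50000 nM in this assay, at which 2 of the 3 values shown sit.
Compound 3 gives > 50000 nM, which is a limit of the assay and not a number. Only the 3-sulfamoylphenyl group of compound 2 gives a readable value here, and the step between the two methyl-bearing compounds cannot be read.

The compounds shown leave open whether a phenyl group bearing a carboxylic acid or an amine instead of the sulfamoyl group would also give a readable value in this assay.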